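Side-chain variation on the shared core: hydroxyethyl to carboxy

The compounds below may be only part of what the source reports. "The series", "measured", "known", "first", "only" and "open" are said of these compounds alone.

Measured so far:
compound 1 `C[C@@H](O)Cc1cc(-c2ccnc3[nH]nc(C(F)(F)F)c23)cc(C2(C#N)CC2)c1`: 34 nM
compound 2 `COCC(O)Cc1cc(-c2ccnc3[nH]nc(C(F)(F)F)c23)cc(C2(C#N)CC2)c1`: 77 nM

Both were tested in an assay on isolated protein for inhibition of protein kinase C epsilon type (Homo sapiens), read by coupled enzyme assay (on this read-out higher numbers stand for weaker inhibition and lower numbers for stronger inhibition), where compound 1 gives 34 nM, the lowest of the two numbers. Going by the values given here, the only step measured so far, a 2.3-fold higher number from compound 1 to compound 2 (0.36 log units; beyond the scatter), moved the number upward by a modest amount.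

Compound 3 `N#CC1(c2cc(CC(=O)O)cc(-c3ccnc4[nH]nc(C(F)(F)F)c34)c2)CC1` is not yet measured. It differs from compound 1 by carboxy in place of 1-hydroxyethyl on a saturated chain carbon bound to an aromatic carbon. Among the compounds with values here, the step from compound 1 to compound 2 is the only guide, and it is a different change at the same place; a modest upward move is expected, a 2.9-fold higher number from compound 1 to compound 3 (0.47 log units; beyond the scatter). For compound 3 the estimate is 100 nM, within 30 nM to 350 nM.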

Compound 3, inhibition constant: 446 nM
The estimate for compound 3 lay 4.5-fold (0.65 log units) below the measured number, and the stated range ends below it.
By their numbers in this assay, from the lowest: compound 1; then compound 2; then compound 3.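

In this assay, carboxy in place of 1-hydroxyethyl gives a 13-fold higher number from compound 1 to compound 3 (1.12 log units; beyond the scatter), a large step, showing that this position does not accept every side-chain change equally. Carboxy also gives a 5.8-fold higher number from compound 2 to compound 3 (0.76 log units; beyond the scatter), so 1-hydroxy-2-methoxyethyl remains the better-tolerated of these two replacements on this read-out. Nothing available here bears on what lies behind these steps. Open, as far as these compounds go, is whether an amine or a primary amide at this place would stay close to compound 1 or track compound 3. From the compounds shown here alone, a longer chain ending in carboxy also remains open.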